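The compounds below may be only part of what the source reports. "The series", "measured", "known", "first", "only" and "open" are said of these compounds alone.

Measured compounds:
- Compound 1, `CCCCOC(=O)Nc1ccc2ccn(Cc3ccc(C(=O)O)cc3OC)c2c1`: 155 nM
- Compound 2, `COc1cc(C(=O)O)ccc1Cn1ccc2ccc(NC(=O)OC3CCCC3)cc21`: 15.7 nM
- Compound 3, `COc1cc(C(=O)NS(=O)(=O)c2ccccc2C)ccc1Cn1ccc2ccc(NC(=O)CC3CCCC3)cc21`: 0.106 nM

In a functional assay on trachea for agonist activity at cysteinyl leukotriene receptor (Homo sapiens) (on this read-out higher numbers stand for weaker inhibition and lower numbers for stronger inhibition), compound 3 gives the lowest number of the three; compound 2 sits nearest to it and compound 1 furthest, both separated from it by margins beyond the scatter. Compound 4, `COc1cc(C(=O)O)ccc1Cn1ccc2ccc(NC(=O)CC3CCCC3)cc21`, has not been measured. It differs from compound 3 in one place: hydroxy in place of ((2-methylphenyl)sulfonyl)amino on a carbonyl carbon. Within the data shown here, no measured step touches this position; the only step available, a 9.9-fold lower number from compound 1 to compound 2 (0.99 log units; beyond the scatter), concerns a different part of the molecule and so offers no direct guide. What the values do show is that compound 2, which carries the same hydroxy on the carbonyl carbon as compound 4 but a different group on the shared core, stands far from compound 3. The author therefore expects compound 4 to move back toward the region occupied by compound 2, an estimated step of a 47-fold higher number from compound 3 to compound 4 (1.67 log units; beyond the scatter), giving a higher number in this assay. The estimate for compound 4 is 5 nM, with a range from 1 nM to 30 nM.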

Compound 4, antagonist equilibrium constant: 20.7 nM
Compound 4: middle estimate off by 4.1-fold (0.62 log units), on the low side; low and high end bracket the measured number.
By their numbers in this assay, from the lowest: compound 3; then compounds 2 and 4 (each within the scatter of the next); then compound 1.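

In this assay, the replacement of ((2-methylphenyl)sulfonyl)amino by hydroxy on the carbonyl carbon bearing the aromatic carbon can now be read on its own, and it gives a 200-fold higher number from compound 3 to compound 4 (2.29 log units; beyond the scatter), so this position carries a large share of the low number of compound 3. On the other carbonyl carbon, with hydroxy held in place, cyclopentylmethyl in place of cyclopentyloxy gives a 1.3-fold higher number from compound 2 to compound 4 (0.12 log units; within the scatter), while cyclopentylmethyl in place of butoxy gives a 7.5-fold lower number from compound 1 to compound 4 (0.87 log units; beyond the scatter). The compounds shown offer no measurement that accounts for the size of these steps.

As far as these compounds go, it remains open whether the whole ((2-methylphenyl)sulfonyl)amino group is needed, since a methylsulfonylamino or phenylsulfonylamino group on the same carbonyl carbon would separate its parts. From the compounds shown here alone, it also remains open whether the step would be of similar size with cyclopentyloxy or butoxy on the other carbonyl carbon.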